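The source may report more compounds than this note shows. Statements on the series, on what has been measured and on what is new or still open speak of the compounds shown alone.

Three compounds share one core and differ only in the ring attached to the carbonyl. Compound 1 `O=C(/C=C/c1ccc2c(c1)B(O)OC2)c1ccccc1` carries an unsubstituted phenyl ring, compound 2 `Cc1ccc(C(=O)/C=C/c2ccc3c(c2)B(O)OC3)cc1` a 4-methylphenyl, and compound 3 `Cc1cccc(C(=O)/C=C/c2ccc3c(c2)B(O)OC3)c1` a 3-methylphenyl. In a functional assay on MDA-MB-231 cells (Homo sapiens) for cytotoxicity, read by MTT assay, with a stated time of 48 h (on this read-out lower numbers stand for stronger inhibition and higher numbers for weaker inhibition), compound 1 gives 2300 nM, compound 2 gives 6500 nM, and compound 3 gives 4500 nM. The number for compound 3 lies between the other two, yet its separation from each is small: the step of a 1.4-fold lower number from compound 2 to compound 3 (0.16 log units; within the scatter) and the step of a 2.0-fold higher number from compound 1 to compound 3 (0.29 log units; within the scatter) both fall within the scatter, so compound 3 cannot be told apart from either neighbour with confidence.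

Compound 4 `Cc1ccc(C(=O)/C=C/c2ccc3c(c2)B(O)OC3)cc1C` is obtained from compound 3 by one change: methyl in place of hydrogen on an aromatic carbon. Two measured steps describe the same kind of change, a methyl entering the ring on the carbonyl carbon. The first, a 2.8-fold higher number from compound 1 to compound 2 (0.45 log units; beyond the scatter), was modest but beyond the scatter; the second, a 2.0-fold higher number from compound 1 to compound 3 (0.29 log units; within the scatter), stayed within it. Both pushed the number upward. A second methyl on that ring is therefore expected to nudge the number upward once more, by a modest margin, giving a 1.8-fold higher number from compound 3 to compound 4 (0.25 log units; within the scatter). Compound 4 is estimated at 8000 nM, within a range from 3500 nM to 18000 nM.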

Compound 4, half-maximal inhibitory concentration: 5300 nM
Beside the measured number, compound 4's estimate is 1.5-fold (0.18 log units) above it; the measured number falls inside the stated range.
By their numbers in this assay, from the lowest: compounds 1, 3, 4 and 2 (each within the scatter of the next, the first and the last beyond it).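

Ortho to a methyl group and para to a large group, the new methyl makes no readable difference in this assay: the step of a 1.2-fold higher number from compound 3 to compound 4 (0.07 log units; within the scatter) and the step of a 1.2-fold lower number from compound 2 to compound 4 (0.09 log units; within the scatter) both lie within the scatter, so compound 4 cannot be told apart from either of the compounds with one methyl. Adding a methyl to a ring that already has one therefore gives no clear shift, yet this cannot be called a true weakening of the methyl effect, as the comparison with the step on the unsubstituted ring stays within the scatter: the same change on two cores in this assay, a 2.8-fold higher number (0.45 log units; beyond the scatter) from compound 1 to compound 2 and a 1.2-fold higher number (0.07 log units; within the scatter) from compound 3 to compound 4, 2.4-fold (0.38 log units) apart, within the scatter of two such steps. The other pair of steps gives the same answer, so the effect of this change cannot be shown to depend on the core: the same change on two cores in this assay, a 2.0-fold higher number (0.29 log units; within the scatter) from compound 1 to compound 3 and a 1.2-fold lower number (0.09 log units; within the scatter) from compound 2 to compound 4, 2.4-fold (0.38 log units) apart, within the scatter of two such steps.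

On these data alone, only methyl has entered this ring here, so it remains open what a hydroxyl, an amine, a carboxylic acid or a longer chain such as ethyl would do at the same carbon. Also open is whether the small differences among these compounds would persist in cell lines other than this one.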